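The source may hold more compounds than are shown below. What is called first, only, known or untested is meant among the compounds shown, and "the series" means these compounds.

Of the compounds shown here, three built on one shared core have so far been measured in a functional assay on CCRF-CEM cells (Homo sapiens) for inhibition, read by cell counting, with a stated time of 3 days; on this read-out higher numbers stand for weaker inhibition and lower numbers for stronger inhibition. Compound 1 `C=C(Br)C(=O)Nc1cccc(-c2cn3nc(-c4ccc(C)cc4)sc3n2)c1` gives 1700 nM. Compound 2 `C=C(Br)C(=O)Nc1cccc(-c2cn3c(-c4ccccc4)csc3n2)c1` gives 2800 nM. Compound 3 `C=C(Br)C(=O)Nc1cccc(-c2cn3nc(Cc4cccc(OC)c4)sc3n2)c1` gives 3100 nM. As written, the number for compound 3 is the highest of the three, but its gaps to compound 2 and to compound 1 both fall within the scatter, so the three compounds cannot be told apart on this assay. Among the measured compounds shown here, the only single-place step among them, a 1.8-fold higher number from compound 1 to compound 3 (0.26 log units; within the scatter), is likewise within the scatter.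

Compound 4 `C=C(Br)C(=O)Nc1cccc(-c2cn3nc(-c4ccc(Cl)cc4)sc3n2)c1` awaits measurement in this assay. It differs from compound 3 as follows: 4-chlorophenyl in place of 3-methoxybenzyl on an aromatic carbon. The 4-chlorophenyl that enters sits on the aromatic carbon in the same direct way as the 4-methylphenyl of compound 1, so the result for compound 1, 1700 nM, is the closest guide available, while the step of a 1.8-fold higher number from compound 1 to compound 3 (0.26 log units; within the scatter) suggests that exchanging groups at this position moves the number little. Compound 4 is therefore expected to give about 2000 nM, with a range from 900 nM to 4500 nM. The estimated step is a 1.6-fold lower number from compound 3 to compound 4 (0.19 log units; within the scatter), which would again lie within the scatter.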

Compound 4, half-maximal inhibitory concentration: 3200 nM
For compound 4 the middle estimate is 1.6-fold (0.20 log units) below the measured one; measured number inside the range.
By their numbers in this assay, from the lowest: compounds 1, 2, 3 and 4 (each within the scatter of the next).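

In this assay, the position on the five-membered aromatic ring now has three groups with single-place steps between them, and none of these steps separates the compounds. Replacing 3-methoxybenzyl with 4-chlorophenyl gives a 1.0-fold higher number from compound 3 to compound 4 (0.01 log units; within the scatter), and chloro in place of methyl on an aromatic carbon gives a 1.9-fold higher number from compound 1 to compound 4 (0.27 log units; within the scatter). Both steps lie within the scatter, so across compounds 1, 3 and 4 neither the exchange of the whole group nor the smaller exchange of chloro for methyl can be told apart on this read-out. No other evidence bears on this result.

All three groups at this position carry a six-membered aromatic ring of carbon only, so the compounds shown leave open whether a group without such a ring, for example an amine, a carboxylic acid or a longer alkyl chain, would stay within the scatter of these numbers. They also leave open whether a ring containing nitrogen, such as pyridine, would do so in place of the 4-chlorophenyl of compound 4.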